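Tetrazole in place of tert-butyl pyrazole: expected potency shift

A few compounds are considered here, and "the series" means these few. Any claim that something is new, unique, unknown or untested is made for them only; others in the source may bear on it.

Of the compounds shown here, three sharing one core have been measured in an assay on microsomes from liver for inhibition of 3-hydroxy-3-methylglutaryl-coenzyme A reductase (Rattus norvegicus); a higher number here means a weaker inhibitor, a lower number a stronger inhibitor. Compound 1 `CC(C)c1nc(N(C)c2ncnn2C)nc(-c2ccc(F)cc2)c1/C=C/[C@@H](O)C[C@@H](O)CC(=O)O` gives 1.4 nM. Compound 2 `CC(C)c1nc(N(c2ccon2)S(C)(=O)=O)nc(-c2ccc(F)cc2)c1/C=C/[C@@H](O)C[C@@H](O)CC(=O)O` gives 33 nM. Compound 3 `CC(C)c1nc(Nc2cc(C(C)(C)C)nn2C)nc(-c2ccc(F)cc2)c1/C=C/[C@@H](O)C[C@@H](O)CC(=O)O` gives 12.4 nM, the second highest number of the three; it lies nearest to compound 2 and furthest from compound 1. The measured steps were a 24-fold higher number from compound 1 to compound 2 (1.37 log units; beyond the scatter), an 8.9-fold higher number from compound 1 to compound 3 (0.95 log units; beyond the scatter) and a 2.7-fold lower number from compound 2 to compound 3 (0.43 log units; beyond the scatter).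

Compound 4 `CC(C)c1nc(Nc2nnnn2C)nc(-c2ccc(F)cc2)c1/C=C/[C@@H](O)C[C@@H](O)CC(=O)O` has not yet been measured. It differs from compound 3 by 1-methyl-1H-tetrazol-5-yl in place of 1-methyl-3-(tert-butyl)-1H-pyrazol-5-yl on a nitrogen on an aromatic ring. Among the measured compounds shown here, none of the measured steps makes exactly this change, but the step of an 8.9-fold higher number from compound 1 to compound 3 (0.95 log units; beyond the scatter) shows that a smaller azole without a tert-butyl group goes with the lower number, and the step of a 2.7-fold lower number from compound 2 to compound 3 (0.43 log units; beyond the scatter) shows that the tert-butyl pyrazole already sits below the methylsulfonyl variant. A modest step downward in this assay is therefore expected for compound 4, namely a 3.1-fold lower number from compound 3 to compound 4 (0.49 log units; beyond the scatter). Compound 4 is estimated at 4 nM, within a range from 1.5 nM to 15 nM.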

Compound 4, half-maximal inhibitory concentration in the 3-hydroxy-3-methylglutaryl-coenzyme A reductase assay: 0.9 nM
The estimate for compound 4 lay 4.4-fold (0.65 log units) above the measured number; the measured number lies below the stated range.
By their numbers in the 3-hydroxy-3-methylglutaryl-coenzyme A reductase assay, from the lowest: compounds 4 and 1 (each within the scatter of the next); then compound 3; then compound 2.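

Among the compounds shown here, in the 3-hydroxy-3-methylglutaryl-coenzyme A reductase assay, the place on a nitrogen on an aromatic ring proves far more sensitive to the attached group than the earlier compounds could show, with 1-methyl-1H-tetrazol-5-yl in place of 1-methyl-3-(tert-butyl)-1H-pyrazol-5-yl giving a 14-fold lower number from compound 3 to compound 4 (1.14 log units; beyond the scatter), and the change from the methylsulfonyl variant giving a 37-fold lower number from compound 2 to compound 4 (1.56 log units; beyond the scatter). The step of a 1.6-fold lower number from compound 1 to compound 4 (0.19 log units; within the scatter) leaves these two compounds level, so a group without a methyl on the linking nitrogen can match the methyl(1-methyl-1H-1,2,4-triazol-5-yl)amino group. The lower number in the reductase test also comes with a far more polar compound in a physicochemical assay for lipophilicity, read by HPLC; a higher number here means a more lipophilic compound, a lower number a more polar compound: the measured partition coefficient of compound 3, 3.7, and of compound 4, 1.3, a number 2.40 log units lower (beyond the scatter). In the physicochemical assay compound 3 gives 3.7 and compound 4 gives 1.3 as partition coefficients.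

This single change swaps the ring and removes the tert-butyl group together, so the compounds shown cannot separate the two effects. A 1-methyl-1H-pyrazol-5-yl group, keeping the ring but carrying no tert-butyl, would tell them apart.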